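Phenol acidity across the thiocarbamate series: compound 4

A few compounds are considered here, and "the series" means these few. Any claim that something is new, unique, unknown or untested is made for them only; others in the source may bear on it.

Working notes on a physicochemical assay for acid dissociation, for a small set of thiocarbamates. Compound 1 `O=[N+]([O-])c1ccc(Sc2ccc(NC(=S)Oc3ccc(O)cc3)cc2)cc1` gives 9.21 in this assay. Compound 2 `Oc1ccc(OC(=S)Nc2ccc(Nc3ccc(C(F)(F)F)cc3)cc2)cc1` gives 9.23, the highest of the three numbers, though its nearest neighbour is compound 1, a difference within the scatter, and its furthest is compound 3, also within the scatter. Compound 3 `CC(=O)Nc1ccc(OC(=S)Nc2ccc(Nc3ccc(C(F)(F)F)cc3)cc2)cc1` gives 9.05. Among the compounds with values here, the only single-point comparison among measured compounds is a number 0.18 log units lower from compound 2 to compound 3 (within the scatter), acetamido in place of hydroxy on an aromatic carbon, and even that change at the proton-bearing end of the molecule stayed inside the scatter.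

Compound 4 `O=[N+]([O-])c1ccc(Nc2ccc(NC(=S)Oc3ccc(O)cc3)cc2)cc1` is not yet measured. It differs from compound 2 by nitro in place of trifluoromethyl on an aromatic carbon, a change sitting para to a large group on the ring far from the phenol. Within the data shown here, no measured step addresses this exact exchange; the closest evidence is that compound 1 and compound 2, which differ in their distal ring, agree within the scatter, and that the one measured step, from compound 2 to compound 3, was itself small. The expected step of a number 0.03 log units lower from compound 2 to compound 4 (within the scatter) is therefore none beyond the scatter. Compound 4 is estimated at 9.2, with a range of 8.9 to 9.5.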

Compound 4, acid dissociation constant: 9.22
Compound 4: middle estimate off by 0.02 log units, on the low side; measured number inside the range.
By their numbers in this assay, from the lowest: compounds 3, 1, 4 and 2 (each within the scatter of the next).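

Within the data shown here, the step in this assay reads a number 0.01 log units lower from compound 2 to compound 4 (within the scatter), and it gives the first direct measurement at this position, on an aromatic carbon para to a large group; the only earlier step, a number 0.18 log units lower from compound 2 to compound 3 (within the scatter), was an exchange of hydroxy for acetamido in a different place. Within this matched pair, nitro in place of trifluoromethyl replaces a group with no hydrogen-bond acceptors by one with two, and the carbon-and-fluorine group by a nitrogen-and-oxygen group, yet the step stays within the scatter, so the read-out does not separate these two groups at this position. No measurement here offers an explanation for this result.

Only these two groups have been compared at this position, so the compounds shown leave open whether an amine, a carboxylic acid or a longer chain in the same place would also stay within the scatter of compound 2. Also open, on these data alone, is whether trifluoromethyl in place of nitro on the core of compound 1 would give an equally small step, which would show whether this reading carries over to a second core.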